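Swapping the side chain on the shared core of compound 3

A few compounds are considered here, and "the series" means these few. Any claim that something is new, unique, unknown or untested is made for them only; others in the source may bear on it.

In an assay on a protein complex for inhibition of CDK8/Cyclin C (Homo sapiens), with a stated time of 1 h, tested at 10 uM (on this read-out lower numbers stand for less inhibition and higher numbers for more inhibition at the one concentration tested (going by the name of the read-out)), compound 1 `NNC(=O)CCc1ccncc1-c1ccc2ccccc2c1` gives 102%, compound 2 `CNC(=O)CCc1ccncc1-c1ccc2ccccc2c1` gives 100% and compound 3 `CN(C)C(=O)/C=C/c1ccncc1-c1ccc2ccccc2c1` gives 100%. Compound 3 is level with compound 2, and both sit a little under compound 1, all within the scatter. Compound 4 `COC(=O)COc1ccncc1-c1ccc2ccccc2c1` is not yet measured; it differs from compound 3 as follows: (methoxycarbonyl)methoxy in place of 2-(dimethylcarbamoyl)ethenyl on an aromatic carbon. Among the measured compounds shown here, the steps that bear on this change the same place on the ring: a number 2 percentage points lower from compound 1 to compound 3 (within the scatter) and no change at the digits printed from compound 2 to compound 3 (within the scatter). Each stayed within the scatter, so the side chain seems to matter little here, though the new group is unlike any tried. A step of a number 5 percentage points lower from compound 3 to compound 4 (within the scatter) is expected in this assay. Compound 4 is therefore estimated at 95%, between 75% and 105%.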

Compound 4, a percentage reported as inhibition, at one concentration (the size of the read-out at that concentration, not a potency): 11%
Compound 4: middle estimate off by 84 percentage points, on the high side; the measured number lies below the stated range.
By their numbers in this assay, from the lowest: compound 4; then compounds 2, 3 and 1 (each within the scatter of the next).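

Side chains on this aromatic carbon are not interchangeable: in this assay (methoxycarbonyl)methoxy gives a number 89 percentage points lower from compound 3 to compound 4 (beyond the scatter) and a number 89 percentage points lower from compound 2 to compound 4 (beyond the scatter) and a number 91 percentage points lower from compound 1 to compound 4 (beyond the scatter). Among the compounds shown here, the earlier side chains all stayed within the scatter of one another, so only this change reveals that the position can respond strongly. Nothing available explains the drop.

This single change replaces the amide with an ester and also adds an oxygen on the ring, leaving their separate contributions open. As far as these compounds go, how a carboxylic acid or an amine on this chain would read also remains open.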